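The compounds below may be only part of what the source reports. "The series", "measured", "known", "first", "only" and "open" are said of these compounds alone.

Compound 1 `O=S(=O)(c1cc(Cl)cc(Cl)c1)c1cnc2cc(F)ccc2c1-c1ccc(Cl)cc1` and compound 2 `O=S(=O)(c1cc(Cl)cc(Cl)c1)c1cnc2cc(F)ccc2c1-c1ccc(F)cc1` share a core and differ only in fluoro in place of chloro on an aromatic carbon. In an ADME assay on microsomes from liver (Rattus norvegicus) for metabolic stability, tested at 2.5 uM (a higher number here means faster removal of the compound, a lower number slower removal), compound 1 gives 0.77 mL/min, and compound 2 gives 1.15 mL/min, a step of a 1.5-fold higher number from compound 1 to compound 2 (0.17 log units; within the scatter). Compound 3 `O=S(=O)(c1ccc(F)cc1)c1cnc2ccc(Cl)cc2c1-c1ccc(Cl)cc1` has a core whose difference from compound 1 is not broken down here; in this assay compound 3 gives 0.2 mL/min. Compound 4 `O=S(=O)(c1ccc(F)cc1)c1cnc2ccc(F)cc2c1-c1ccc(Cl)cc1` differs from compound 3 by fluoro in place of chloro on an aromatic carbon. This is the same kind of change as from compound 1 to compound 2, but the place differs: there the carbon sat on a ring of carbon only, para to a large group, while here it sits on a ring that is part of a fused system, meta and para to a fused ring. Because a 1.5-fold higher number from compound 1 to compound 2 (0.17 log units; within the scatter) stayed within the scatter, compound 4 is expected to show a similarly small step, a 1.3-fold higher number from compound 3 to compound 4 (0.10 log units; within the scatter). Compound 4 is estimated at 0.25 mL/min, between 0.12 mL/min and 0.5 mL/min.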

Compound 4, intrinsic clearance in a liver preparation (reported as CLH), per the amount of preparation that the assay uses: 0.4 mL/min
Beside the measured number, compound 4's estimate is 1.6-fold (0.20 log units) below it, and the stated range covers the measured number.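

In this assay, putting fluoro in place of chloro on an aromatic carbon gives a 2.0-fold higher number from compound 3 to compound 4 (0.30 log units; within the scatter). Set beside the earlier case of the same change, the two steps agree: the same change on two cores in this assay, a 1.5-fold higher number (0.17 log units; within the scatter) from compound 1 to compound 2 and a 2.0-fold higher number (0.30 log units; within the scatter) from compound 3 to compound 4, 1.3-fold (0.13 log units) apart, within the scatter of two such steps So in these two pairs the change carries from one core to the other, and in neither pair does it move the number by more than repeat measurements would; two pairs, with the change at a different place in each, do not show that this holds on other cores or at other places.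

Still open, from the compounds shown here alone, is how the number would respond at this aromatic carbon to a group other than these two halogens, such as a nitrile, a methoxy group or an amine.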